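The source may hold more compounds than are shown below. What is called first, only, known or untested is meant among the compounds shown, and "the series" means these compounds.

Two measured compounds share one core and differ only in the group on the amide-type nitrogen. Compound 1 `CCCNC(=O)CC1CCc2cc(OC)c(OC)cc21` carries a propyl there, while compound 2 `COc1cc2c(cc1OC)C(CC(=O)NC1CCCC1)CC2` carries a cyclopentyl. In a functional assay on the whole organism (strain Wistar) for inhibition, with Rattus norvegicus as the target, read by paw edema, with stated times of 60 min and 24 h, at a dose of 100 mg/kg by the oral route (a higher number here means more inhibition at the dose given (going by the name of the read-out), a lower number less inhibition), compound 1 gives 26.7%, and compound 2 gives 46.7%. Going by the values given here, the single measured step, a number 20 percentage points higher from compound 1 to compound 2 (beyond the scatter), lies beyond the usual scatter, so compound 2 stands higher of the two numbers, with compound 1 as its only comparison.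

Compound 3 `COc1cc2c(cc1OC)C(CC(=O)NCc1ccccc1)CC2` has not yet been measured in this assay. It differs from compound 2 in one place: benzyl in place of cyclopentyl on an amide-type nitrogen. Among the compounds with values here, only the step of a number 20 percentage points higher from compound 1 to compound 2 (beyond the scatter) bears on this change, and it went upward when a ring replaced an open chain on the same nitrogen. Benzyl keeps a ring at that position, now an aromatic one, so the expectation for compound 3 is a number close to that of compound 2, or modestly above it, with the step of a number 3.3 percentage points higher from compound 2 to compound 3 (within the scatter) expected. The estimated value for compound 3 is 50%, within a range from 30% to 70%.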

Compound 3, a percentage reported as inhibition, in the whole organism at one dose (the size of the read-out at that dose, not a potency): 43.3%
Estimate against measurement, compound 3: 6.7 percentage points above; measured number inside the range.
By their numbers in this assay, from the lowest: compound 1; then compounds 3 and 2 (each within the scatter of the next).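

Swapping the saturated cyclopentyl for the aromatic benzyl on the amide-type nitrogen gives two numbers that this assay cannot separate (a number 3.4 percentage points lower from compound 2 to compound 3 (within the scatter)), so at this position an aromatic ring and a non-aromatic ring of carbon only read alike. The earlier comparison rested on a single ring-bearing group, and benzyl now supplies a second one that also clears the propyl of compound 1 (a number 16.6 percentage points higher from compound 1 to compound 3 (beyond the scatter)), matching the earlier cyclopentyl step (a number 20 percentage points higher from compound 1 to compound 2 (beyond the scatter)), with neither ring-bearing compound going against this small pattern. Going by these compounds alone, the data show only this pattern in the numbers and offer no measurement that explains either step or the likeness of the two rings.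

An open chain such as pentyl would show whether a ring matters at this nitrogen or whether a larger group of any shape gives the same reading. Cyclohexyl, phenyl placed directly on the nitrogen, or a benzyl carrying a methoxy group or a carboxylic acid would test how much change this position accepts, and each reading would still describe a single dose rather than a potency.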